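The source may report more compounds than this note shows. Statements on the series, on what has been measured and on what is new or still open speak of the compounds shown alone.

Measured in an in vitro ADME assay on microsomes from liver (Homo sapiens) for metabolic stability (on this read-out higher numbers stand for fast clearance and lower numbers for slow clearance), so far:
- Compound 1 `CC(=O)N(Cc1ccccc1-c1ccccc1)[C@H]1CCNC1` gives < 7 mL.min-1.g-1 (a limit)
- Compound 2 `CC(C)CC(=O)N(Cc1ccccc1-c1ccccc1)[C@H]1CCNC1` gives 9 mL.min-1.g-1 (a number)

Among the compounds with values here, compound 2 at 9 mL.min-1.g-1 holds the only number so far. Compound 1 stands at < 7 mL.min-1.g-1 as a limit of the assay and not a number.

Compound 3 `CCS(=O)(=O)N(Cc1ccccc1-c1ccccc1)[C@H]1CCNC1` carries ethylsulfonyl in place of isobutylcarbonyl on an amine nitrogen and keeps the rest of the structure of compound 2. Within the data shown here, the sole measured step is an at least 1.2-fold higher number from compound 1 to compound 2 (0.10 log units; that floor lies within the scatter) and it changes only the chain on the carbonyl. Among the measured compounds shown here, no measured step replaces the carbonyl itself, so that step is a weak guide. With it as the one reference, no change beyond the scatter is expected in this assay for this replacement. The expected size is a 1.3-fold lower number from compound 2 to compound 3 (0.11 log units; within the scatter) and it stays within the scatter. For compound 3 the estimate is 7 mL.min-1.g-1 with an expected range from 4 mL.min-1.g-1 to 14 mL.min-1.g-1 in this read-out.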

Compound 3, intrinsic clearance in microsomes: < 7 mL.min-1.g-1
Compound 3: only a limit was reported; the forecaster's own chance of this, stated with the estimate: 50%; the middle value sits exactly at the limit.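

Within the data shown here, on the amine nitrogen whose other neighbours are a saturated chain carbon and a saturated ring carbon, ethylsulfonyl in place of isobutylcarbonyl is the first change to the carbonyl itself, and in this assay it gives an at least 1.2-fold lower number from compound 2 to compound 3 (0.10 log units; that floor lies within the scatter). Compound 3 gives < 7 mL.min-1.g-1, which is a limit of the assay and not a number. The step between compound 1 and compound 3 cannot be read, and the comparison ends at the lower end of the read-out: the limit of < 7 mL.min-1.g-1 in this assay, at which 2 of the 3 values shown sit.

As far as these compounds go, how far compound 1 and compound 3 lie under that limit stays open, so acetyl and ethylsulfonyl cannot be ranked. Also open, from the compounds shown here alone, is whether a longer chain on the sulfonyl, such as isobutylsulfonyl, or an amine on the chain would bring the result in this assay to a readable number.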